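Replacing the 4-chlorophenyl group of compound 1

A few compounds are considered here, and "the series" means these few. Any claim that something is new, unique, unknown or untested is made for them only; others in the source may bear on it.

In a functional assay, read by Griess assay, with a stated time of 2.5 h (a higher number here means a weaker inhibitor, a lower number a stronger inhibitor), compound 1 `COc1cc(OC)c(OC)cc1/C=C/C(=O)c1ccc(Cl)cc1` gives 2.01 ug/mL, and compound 2 `COc1cc(OC)c(-c2cc(=O)c3cc(Cl)ccc3o2)cc1OC` gives 2.15 ug/mL. Compound 1 has the lower of these two numbers, but the two lie within the scatter of each other, so it holds no real lead over compound 2.

The next compound to be measured is compound 3 `COc1cc(OC)c(OC)cc1/C=C/C(=O)c1cc(Cl)ccc1O`. It keeps the rest of compound 1 and carries 5-chloro-2-hydroxyphenyl in place of 4-chlorophenyl on a carbonyl carbon. The change adds a hydrogen-bond donor and a hydrogen-bond acceptor to the count.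

For the measured compounds named here, no measured pair differing in one place is available, so the data give no direct guide to the size of this step. In this assay, no step beyond the scatter is expected, with a slight lean towards a lower number. Going by the values given here, this expectation rests on the narrow span of the two known numbers, with compound 1 at 2.01 ug/mL as the starting point. The estimated step is a 1.3-fold lower number from compound 1 to compound 3 (0.10 log units; within the scatter). For compound 3 the expected value is 1.6 ug/mL, within an estimated range of 0.6 ug/mL to 4 ug/mL.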

Compound 3, half-maximal inhibitory concentration: 2.32 ug/mL
Compound 3: middle estimate off by 1.5-fold (0.16 log units), on the low side; low and high end bracket the measured number.
By their numbers in this assay, from the lowest: compounds 1, 2 and 3 (each within the scatter of the next).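

For the compounds shown here, the step at this carbonyl carbon, whose other neighbour is a double-bonded chain carbon, is the first single-place comparison in this assay, and exchanging 4-chlorophenyl for 5-chloro-2-hydroxyphenyl gives a 1.2-fold higher number from compound 1 to compound 3 (0.06 log units; within the scatter). The hydrogen-bond donor and hydrogen-bond acceptor that enter with the new group therefore bring no change in this assay that can be told apart from the scatter, although the step replaces the whole aryl group at once and cannot divide any contribution between the hydroxy group and the chlorine. Nothing measured here offers an explanation for this result.

All three compounds lie within the scatter of their neighbours in the ranking, so the compounds shown leave open whether any group on this carbonyl carbon can move the number beyond the scatter at all. From the compounds shown here alone, it also remains open how a 2-methoxyphenyl group, a 2-aminophenyl group or a plain 2-hydroxyphenyl group without chlorine would read in this assay when placed on this carbon.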